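Chloro in place of fluoro in the series

The source may report more compounds than this note shows. Statements on the series, on what has been measured and on what is new or still open speak of the compounds shown alone.

- compound 1 `Cc1ccc2c(O)cc(-c3cccc(Cl)c3)nc2n1` gives 22.9 nM
- compound 2 `Cc1cc(C)c2c(O)cc(-c3cccc(F)c3)nc2n1` gives 33.1 nM
- compound 3 `Cc1cc(C)c2c(O)cc(-c3cccc(Cl)c3)nc2n1` is not yet measured

In a functional assay on SF-295 cells (Homo sapiens) for antiproliferative activity (on this read-out higher numbers stand for weaker inhibition of growth and lower numbers for stronger inhibition of growth), compound 2 gives 33.1 nM and compound 1 gives 22.9 nM, two values within the usual scatter of each other. Compound 3 differs from compound 2 by chloro in place of fluoro on an aromatic carbon. For the measured compounds named here, no measured pair shows this change alone, so no shift beyond the scatter is expected in this assay, in either direction. Compound 1 also carries chloro and gives 22.9 nM, which fits that expectation. The estimated change is a 1.2-fold lower number from compound 2 to compound 3 (0.09 log units; within the scatter). For compound 3 the estimated value is 27 nM, with an expected range of 12 nM to 60 nM.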

Compound 3, concentration for 50% growth inhibition: 47.9 nM
Estimate against measurement, compound 3: 1.8-fold (0.25 log units) below; measured number inside the range.
By their numbers in this assay, from the lowest: compounds 1, 2 and 3 (each within the scatter of the next, the first and the last beyond it).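

In this assay, chloro in place of fluoro on an aromatic carbon, meta to a large group, stays within the scatter (a 1.4-fold higher number from compound 2 to compound 3 (0.16 log units; within the scatter)). For the compounds shown here, with chloro held constant, methyl in place of hydrogen on an aromatic carbon gives a modest step beyond the scatter (a 2.1-fold higher number from compound 1 to compound 3 (0.32 log units; beyond the scatter)), the only step here that exceeds it. Nothing at hand gives a cause for either step.

Going by these compounds, whether methoxy or an amine at the chloro position would shift the number remains open. Also open, on these data alone, is whether the methyl step holds with fluoro in place of chloro.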